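A few compounds are considered here, and "the series" means these few. Any claim that something is new, unique, unknown or untested is made for them only; others in the source may bear on it.

Measured so far:
- Compound 1 `C=CC(=O)NCc1coc(-c2c(N)ncnc2Nc2ccc(OCc3cccc(F)c3)c(Cl)c2)n1`: in an in vitro ADME assay on microsomes from liver (Canis lupus familiaris) for metabolic stability, tested at 5 uM (a lower number here means that the compound disappears faster, a higher number that the compound lasts longer), compound 1 gives > 1.66 h; this is a limit of the assay, not a number.
- Compound 2 `C=CC(=O)NCc1coc(-c2c(N)ncnc2Nc2ccc(Oc3cc(Cl)ccc3Cl)c(Cl)c2)n1`: in this assay compound 2 gives > 1.66 h; again a limit of the assay.
- Compound 3 `C=CC(=O)NCc1coc(-c2c(N)ncnc2Nc2ccc(Oc3ccccn3)c(Cl)c2)n1`: in this assay compound 3 gives 0.4 h.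

Among the compounds with values here, compound 3 therefore holds the only read number in the set; the other two values sit at the limit of > 1.66 h in this assay, at which 2 of the 3 values shown sit. Both readable steps run the same way: an at least 4.1-fold lower number from compound 1 to compound 3 (0.61 log units; beyond the scatter) and an at least 4.1-fold lower number from compound 2 to compound 3 (0.61 log units; beyond the scatter). The step between compound 1 and compound 2 cannot be read, as both rest on limits.

Compound 4 `C=CC(=O)NCc1coc(-c2c(N)ncnc2Nc2ccc(F)c(Cl)c2)n1` is not yet measured. It differs from compound 3 in one place: fluoro in place of (pyridin-2-yl)oxy on an aromatic carbon, on an aromatic carbon of a six-membered aromatic ring of carbon only, ortho to a chloro group and para to a large group. The two measured steps both show that the pyridin-2-yloxy group goes with the short half-life; removing it in favour of fluoro is expected to reverse that, so the step from compound 3 to compound 4 is estimated as a 3.0-fold higher number from compound 3 to compound 4 (0.48 log units; beyond the scatter) in this assay. Compound 4 is expected to give about 1.2 h, within 0.4 h to 3 h, with a fair chance that only a limit is reported.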

Compound 4, half-life: 0.15 h
The estimate for compound 4 lay 8.0-fold (0.90 log units) above the measured number; the measured number lies below the stated range.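

At this position, replacing (pyridin-2-yl)oxy with fluoro gives a 2.7-fold lower number from compound 3 to compound 4 (0.43 log units; beyond the scatter) in this assay, so the pyridin-2-yl ether no longer marks the low end of the set. The drop is larger against the other two ethers, with an at least 11-fold lower number from compound 2 to compound 4 (1.04 log units; beyond the scatter) and an at least 11-fold lower number from compound 1 to compound 4 (1.04 log units; beyond the scatter). All three ring-bearing ethers on this aromatic carbon therefore outlast fluoro, and none of the four compounds goes against this, although the ethers themselves differ, since (pyridin-2-yl)oxy falls short of the other two.

From the compounds shown here alone, it remains open whether a methoxy group or an amine on this carbon would track fluoro or the ring-bearing ethers. The step between compound 1 and compound 2 cannot be read, and how far these two compounds outlast the others is unknown: the limit of > 1.66 h in this assay, at which 2 of the 4 values shown sit.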